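A few compounds are considered here, and "the series" means these few. Any claim that something is new, unique, unknown or untested is made for them only; others in the source may bear on it.

For the measured compounds named here, in an assay on isolated protein for inhibition of DNA topoisomerase 1 (Homo sapiens), with a stated time of 30 min, tested at 100 uM (a lower number here means a weaker effect, a higher number a stronger effect of the compound at the concentration tested), compound 2 `Oc1cccc(-c2cc(-c3ccsc3)nc(-c3cccc(Cl)c3)c2)c1` gives 26.2%, the higher of the two numbers so far. The other measured compound, compound 1 `Oc1cccc(-c2cc(-c3cccs3)nc(-c3ccccc3Cl)c2)c1`, gives 2.7% in this assay, and the gap between the two lies beyond the usual scatter of the measurement. Going by the values given here, no pair of measured compounds differs in only one place, so no single change has yet been tied to a shift in this assay.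

Compound 3 `Oc1cccc(-c2cc(-c3cccc(Cl)c3)nc(-c3cccs3)c2)c1` has not been measured. It differs from compound 2 in one place: thiophen-2-yl in place of thiophen-3-yl on an aromatic carbon. Among the compounds with values here, with no comparable step in hand, the expected effect of this change is modest, either none beyond the scatter or a small loss, and the step from compound 2 to compound 3 is estimated as a number 6.2 percentage points lower from compound 2 to compound 3 (within the scatter). Compound 3 is therefore expected to give about 20% in this assay, within a range from 5% to 40%.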

Compound 3, a percentage reported as inhibition, at one concentration (the size of the read-out at that concentration, not a potency): 7.6%
Compound 3: middle estimate off by 12.4 percentage points, on the high side; the range from low to high includes it.
By their numbers in this assay, from the lowest: compounds 1 and 3 (each within the scatter of the next); then compound 2.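

At the place next to the ring nitrogen, with the 3-chlorophenyl group held constant, the shift of the thiophene attachment gives the first single change tied to a shift in this assay (a number 18.6 percentage points lower from compound 2 to compound 3 (beyond the scatter)), even though thiophen-3-yl and thiophen-2-yl have the same atoms and the same counts. With thiophen-2-yl held constant, 3-chlorophenyl in place of 2-chlorophenyl gives no shift that can be told from the scatter (a number 4.9 percentage points higher from compound 1 to compound 3 (within the scatter)). Nothing measured here accounts for the difference between the two thiophene attachments.

The compounds shown leave open whether thiophen-3-yl would also give the higher number with a 2-chlorophenyl group on the core. They also leave open what a furan-3-yl group or an amine would give at this place.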